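From methylsulfamoyl to methylsulfanyl on a shared core

The compounds below may be only part of what the source reports. "The series", "measured", "known", "first", "only" and "open" are said of these compounds alone.

Three compounds share one core and differ in one group. In a functional assay on the whole organism with Rattus norvegicus as the target (a lower number here means that less compound is needed, a higher number that more compound is needed for the effect), compound 1 `C=CCn1c(=N)sc2cc(OC(F)(F)F)ccc21` gives 7 mg/kg and compound 2 `N=c1sc2cc(OC(F)(F)F)ccc2n1CC(N)=O` gives 7 mg/kg while compound 3 `CNS(=O)(=O)CCn1c(=N)sc2cc(OC(F)(F)F)ccc21` gives 4 mg/kg as its number. Compound 3 therefore stands within the scatter of both others, with no clear lead. Compound 4 `CSCCn1c(=N)sc2cc(OC(F)(F)F)ccc21` differs from it in one place, with methylsulfanyl in place of methylsulfamoyl on a saturated chain carbon, two bonds along the chain from an aromatic nitrogen, and the full count reads methylsulfanyl in place of methylsulfamoyl on a saturated chain carbon, two bonds along the chain from an aromatic nitrogen for this change. Among the measured compounds shown here, three measured steps bear on it, all swaps of the group on that chain: no change at the digits printed from compound 1 to compound 2 (within the scatter) for carbamoyl, then a 1.8-fold lower number from compound 1 to compound 3 (0.24 log units; within the scatter) and a 1.8-fold lower number from compound 2 to compound 3 (0.24 log units; within the scatter) for the methylsulfamoyl end. For the measured compounds named here, none left the scatter, but no measured compound carries methylsulfanyl itself. In this assay no step beyond the scatter is therefore expected, and the estimated step is a 1.5-fold higher number from compound 3 to compound 4 (0.18 log units; within the scatter) for now. For compound 4 the estimated value is 6 mg/kg with an expected range from 3 mg/kg to 12 mg/kg as the likely span.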

Compound 4, dose for half-maximal effect: 1 mg/kg
Compound 4: middle estimate off by 6.0-fold (0.78 log units), on the high side; the measured number lies below the stated range.
By their numbers in this assay, from the lowest: compound 4; then compounds 3, 1 and 2 (each within the scatter of the next).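

Swapping the group on this chain gives a 4.0-fold lower number from compound 3 to compound 4 (0.60 log units; beyond the scatter) in this assay, the first step in this series to pass beyond the scatter. The same holds against the other two groups, with a 7.0-fold lower number from compound 2 to compound 4 (0.85 log units; beyond the scatter) and a 7.0-fold lower number from compound 1 to compound 4 (0.85 log units; beyond the scatter), so this position does respond to what it carries, and 2-(methylsulfanyl)ethyl sets compound 4 apart from compounds 1, 2 and 3. No measurement shown here accounts for the size of these steps.

The compounds shown leave open whether the sulfur atom, the small size of the group or the length of the chain matters most. A methoxy group in the same place, an ethylsulfanyl group, or a longer chain ending in methylsulfanyl would help to separate these possibilities.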